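A trifluoromethyl shift among weak antiproliferative compounds

The source may hold more compounds than are shown below. What is called first, only, known or untested is meant among the compounds shown, and "the series" means these compounds.

Among the measured compounds shown here, only two compounds have numbers so far. In a functional assay on VCaP cells (Homo sapiens) for antiproliferative activity, read by propidium iodide staining, with a stated time of 96 h (on this read-out higher numbers stand for weaker inhibition and lower numbers for stronger inhibition), compound 1 (`CC(O)(CS(=O)(=O)c1cccc(S(F)(F)(F)(F)F)c1)C(=O)Nc1ccc([N+](=O)[O-])c(C(F)(F)F)c1`) gives 24600 nM. In this assay compound 2 (`CC1(C)C(=O)N(c2cccc(S(F)(F)(F)(F)F)c2)C(=S)N1c1ccc(C(F)(F)F)cc1`) gives 54200 nM, the higher of the two numbers and so the weaker inhibition, and the gap between them lies beyond the usual scatter. The two compounds differ in more than one place, so they offer no single-change step to reason from. Compound 3 (`CC1(C)C(=O)N(c2cccc(S(F)(F)(F)(F)F)c2)C(=S)N1c1cccc(C(F)(F)F)c1`) has not yet been measured. It has the same atoms as compound 2, joined differently, with 3-(trifluoromethyl)phenyl in place of 4-(trifluoromethyl)phenyl on an amide-type nitrogen in a ring. For the measured compounds named here, no measured pair shows what such a change does in this assay, so no step beyond the scatter is expected, and the starting point remains compound 2 at 54200 nM. The expected change is a 1.2-fold lower number from compound 2 to compound 3 (0.08 log units; within the scatter). For compound 3 the estimated value is 45000 nM, with an expected range from 18000 nM to 100000 nM.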

Compound 3, half-maximal inhibitory concentration: 100000 nM
Estimate against measurement, compound 3: 2.2-fold (0.35 log units) below, and the stated range covers the measured number.
By their numbers in this assay, from the lowest: compound 1; then compounds 2 and 3 (each within the scatter of the next).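

Placing 3-(trifluoromethyl)phenyl in place of 4-(trifluoromethyl)phenyl on the amide-type nitrogen of the five-membered ring gives a 1.8-fold higher number from compound 2 to compound 3 (0.27 log units; within the scatter), and this is the first single-change pair available in this assay. It shows that, at this place on the ring, two arrangements of the same atoms cannot be told apart in this read-out, so the step offers no sign that the location of the trifluoromethyl group on this phenyl ring matters, though a single pair with numbers this high is a narrow basis for any wider reading. No measurement is available that would account for this result or tie it to any property of either group.

The compounds shown leave open whether the phenyl ring on this nitrogen would respond to a different group, such as a nitrile or an amine, in place of trifluoromethyl, as only one group in two placements has been compared here. Also open, going by these compounds, is whether a longer chain in place of the two methyl groups on the ring would move the number in this assay beyond the scatter.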